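Aryl swap on the amide of a naphthyl hexafluorocarbinol

The source may report more compounds than this note shows. Statements on the series, on what has been measured and on what is new or still open speak of the compounds shown alone.

Compound 3 `O=C(Nc1c(C(O)(C(F)(F)F)C(F)(F)F)ccc2ccccc12)c1cccc(C(F)(F)F)c1` gives 84 nM in an assay on LtK cells with ATP-sensitive inward rectifier potassium channel 11 (Homo sapiens) as the target (on this read-out higher numbers stand for an effect only at larger amounts of compound and lower numbers for an effect already at smaller amounts), the second highest of the three numbers recorded so far. Its nearest neighbour is compound 2 `O=C(Nc1c(C(O)(C(F)(F)F)C(F)(F)F)ccc2ccccc12)C1CCC1`, which gives 45 nM in this assay, and the step of a 1.9-fold higher number from compound 2 to compound 3 (0.27 log units; within the scatter) stays within the scatter. Its furthest neighbour is compound 1 `CCC(CC)C(=O)Nc1c(C(O)(C(F)(F)F)C(F)(F)F)ccc2ccccc12`, which gives 4340 nM in this assay; the step of a 52-fold lower number from compound 1 to compound 3 (1.71 log units; beyond the scatter) is large, as is a 96-fold lower number from compound 1 to compound 2 (1.98 log units; beyond the scatter).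

Compound 4 `O=C(Nc1c(C(O)(C(F)(F)F)C(F)(F)F)ccc2ccccc12)c1ccc(I)cc1` has not yet been measured. It differs from compound 3 in one place: 4-iodophenyl in place of 3-(trifluoromethyl)phenyl on a carbonyl carbon. Among the measured compounds shown here, none of the measured steps exchanges one aryl group for another on the carbonyl carbon, so the step from compound 3 to compound 4 has no direct precedent. What the measured steps do show is that compound 2 and compound 3 lie within the scatter of each other, while only compound 1 stands apart. Compound 4 is therefore expected to show a 1.2-fold higher number from compound 3 to compound 4 (0.08 log units; within the scatter), no step beyond the scatter in this assay. Compound 4 is estimated at 100 nM in this assay, in a range from 30 nM to 350 nM.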

Compound 4, half-maximal effective concentration: 154 nM
For compound 4 the middle estimate is 1.5-fold (0.19 log units) below the measured one, within the range that was stated.
By their numbers in this assay, from the lowest: compounds 2, 3 and 4 (each within the scatter of the next, the first and the last beyond it); then compound 1.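

Exchanging 3-(trifluoromethyl)phenyl for 4-iodophenyl on the carbonyl carbon gives a 1.8-fold higher number from compound 3 to compound 4 (0.26 log units; within the scatter) in this assay, so the two aryl groups cannot be told apart at this position. Compared with the cyclobutyl group, however, 4-iodophenyl opens a modest gap, a 3.4-fold higher number from compound 2 to compound 4 (0.53 log units; beyond the scatter), which the step from compound 2 to compound 3 did not show, while a 28-fold lower number from compound 1 to compound 4 (1.45 log units; beyond the scatter) keeps the pentan-3-yl amide well apart from this aryl amide as well. Nothing available here bears on the reason for these steps.

On these data alone, what a plain phenyl, a 3-iodophenyl or a 4-(trifluoromethyl)phenyl would give on this carbonyl carbon remains open, and with it whether the substituent or its place on the ring matters. Also open, as far as these compounds go, is whether the wide gap between pentan-3-yl and cyclobutyl would extend to an isopropyl or a cyclopentyl group.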